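This account rests on a few compounds, and the source may have more. Where it says the series, first, only, none or still open, it means among the compounds named here.

Compound 1 `Cn1cnc(CN2CCN(c3cccc4[nH]c(-c5ccc(C(C)(C)C)cc5)nc34)CC2)c1`: 33 nM
Compound 2 `CCc1nc(C)c(CN2CCN(c3cccc4[nH]c(-c5ccc(C(C)(C)C)cc5)nc34)CC2)o1`: 37 nM

In an assay on isolated protein for displacement of a labelled ligand from Gonadotropin-releasing hormone receptor (Homo sapiens) (a lower number here means a stronger inhibitor, a higher number a weaker inhibitor), compound 1 has the lowest of the two numbers; its nearest neighbour is compound 2, and the step of a 1.1-fold higher number from compound 1 to compound 2 (0.05 log units; within the scatter). Compound 3 `Cc1nc(CN2CCN(c3cccc4[nH]c(-c5ccc(C(C)(C)C)cc5)nc34)CC2)cn1C` has not yet been measured. It differs from compound 1 by methyl in place of hydrogen on an aromatic carbon. For the measured compounds named here, no measured step adds a methyl to this ring; the only step at hand, a 1.1-fold higher number from compound 1 to compound 2 (0.05 log units; within the scatter), exchanged the whole ring and still stayed within the scatter, so no change beyond the scatter is expected here either. The step is expected to be a 1.1-fold higher number from compound 1 to compound 3 (0.03 log units; within the scatter). Compound 3 is expected to give about 35 nM in this assay, with a likely range from 15 nM to 85 nM.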

Compound 3, half-maximal inhibitory concentration: 10 nM
Compound 3: the middle estimate sits 3.5-fold (0.54 log units) above what was measured, outside the stated range (below it).
By their numbers in this assay, from the lowest: compound 3; then compounds 1 and 2 (each within the scatter of the next).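

In this assay the single methyl on the aromatic carbon between two ring nitrogen atoms gives a 3.3-fold lower number from compound 1 to compound 3 (0.52 log units; beyond the scatter) and so moves the number beyond the scatter, which the exchange of the whole ring in the earlier step had not done. The 1,2-dimethyl-1H-imidazol-4-yl group also stands apart from the oxazole, with a 3.7-fold lower number from compound 2 to compound 3 (0.57 log units; beyond the scatter) as the step, so this carbon responds to a very small change. Nothing at hand tells why this methyl matters. On these data alone, whether an ethyl, a longer chain or an amine on the same carbon would go further remains open.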